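Fluoro for Chloro on the Cyclopropyl Amide

The source may hold more compounds than are shown below. What is called first, only, known or untested is meant among the compounds shown, and "the series" means these compounds.

Of the compounds shown here, two sharing one core have been measured in a functional assay on the whole organism with Mus musculus as the target, at a dose of 100 mg/kg by the intraperitoneal route; on this read-out higher numbers stand for more inhibition at the one dose given (going by the name of the read-out) and lower numbers for less inhibition. Compound 1 `CNC(=O)/C=C1\CCc2ccc(Cl)cc21` carries a methyl on the amide-type nitrogen, and in this assay compound 1 gives 16%. Compound 2 `O=C(/C=C1\CCc2ccc(Cl)cc21)NC1CC1` carries a cyclopropyl there instead, and in this assay compound 2 gives 50%. Going by the values given here, the single measured step, a number 34 percentage points higher from compound 1 to compound 2 (beyond the scatter), lies beyond the scatter, so compound 2 stands highest of the two numbers, with compound 1 as its nearest neighbour.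

Compound 3 `O=C(/C=C1\CCc2ccc(F)cc21)NC1CC1` keeps the cyclopropyl amide of compound 2 and differs from it at one place only: fluoro in place of chloro on an aromatic carbon. Among the compounds with values here, no measured step bears on this exchange of fluoro for chloro; the one step measured concerns cyclopropyl in place of methyl on the amide-type nitrogen, a different part of the molecule, and gives no guide to the size or direction of a change on the aromatic ring. Compound 3 is therefore expected to show in this assay a step of a number 7 percentage points lower from compound 2 to compound 3 (within the scatter), not expected to exceed the scatter. The estimate for compound 3 in this assay is 43%, within a range from 20% to 65%.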

Compound 3, a percentage reported as inhibition, in the whole organism at one dose (the size of the read-out at that dose, not a potency): 100%
Estimate against measurement, compound 3: 57 percentage points below; measured number outside the range, above it.
By their numbers in this assay, from the lowest: compound 1; then compound 2; then compound 3.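

Until now, all the compounds carried chloro on this aromatic carbon, so only the amide-type nitrogen had been shown to move the read-out. In this assay, the exchange of fluoro for chloro gives a number 50 percentage points higher from compound 2 to compound 3 (beyond the scatter), which shows that this position, meta to a fused ring and para to a fused ring, also matters strongly on the cyclopropyl amide. The change is a single heavy atom for a single heavy atom, with no ring, hydrogen-bond donor, hydrogen-bond acceptor or net charge entering or leaving, and the data offered here give no account of why the step is so large.

The compounds shown leave open whether the gain with fluoro depends on the cyclopropyl amide, as fluoro has been seen only alongside cyclopropyl and not alongside methyl on the amide-type nitrogen. They also leave open how this aromatic carbon would respond to hydrogen, a methoxy group or a nitrile, and how a cyclobutyl group on the amide-type nitrogen would compare with cyclopropyl.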